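The compounds below may be only part of what the source reports. "The series", "measured", "known", "first", "only" and "open" are said of these compounds alone.

Measured so far in a functional assay on MOLT-4 cells (Homo sapiens) for inhibition; on this read-out lower numbers stand for stronger inhibition and higher numbers for weaker inhibition:

- compound 1 `O=C1/C(=C/c2ccc(F)cc2)Cc2ccccc21`: 60000 nM
- compound 2 `O=C1/C(=C/c2cccc([N+](=O)[O-])c2)CCCc2ccccc21`: 8820 nM
- compound 3 `O=C1CCCCC/C1=C\c1ccc(Cl)cc1`: 52600 nM

Compound 3, at 52600 nM, is second highest of the three numbers. It cannot be told apart from compound 1 at 60000 nM, since the two lie within the scatter. Compound 2, at 8820 nM, gives a clearly lower number than compound 3, which means stronger inhibition.

The next compound is compound 4 `CN(C)c1ccc(/C=C2\CCCCCC2=O)cc1`, with dimethylamino in place of chloro on an aromatic carbon. Among the compounds with values here, no pair of measured compounds differs in one place only, so nothing here shows directly what this swap does. The expectation is therefore cautious: a small step in this assay towards a lower number, perhaps hardly beyond the scatter. The expected change is a 1.8-fold lower number from compound 3 to compound 4 (0.24 log units; within the scatter). For compound 4 the estimated value is 30000 nM, with an expected range from 10000 nM to 80000 nM.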

Compound 4, half-maximal inhibitory concentration: 57400 nM
Estimate against measurement, compound 4: 1.9-fold (0.28 log units) below, and the stated range covers the measured number.
By their numbers in this assay, from the lowest: compound 2; then compounds 3, 4 and 1 (each within the scatter of the next).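

Within the data shown here, this is the first pair in this assay that differs in one place only, and the swap of chloro for dimethylamino on an aromatic carbon gives a 1.1-fold higher number from compound 3 to compound 4 (0.04 log units; within the scatter) with no change that can be told from the scatter. So at this position, in this seven-membered ketone series as far as these two compounds go, a group of 3 heavy atoms with 1 hydrogen-bond acceptor reads the same as a single chlorine. Nothing measured here says why the number stays put.

Going by these compounds, whether a smaller group such as fluoro or a charged one such as a carboxylic acid on the same carbon would shift the number remains open. So does whether this swap would read the same on the core of compound 1 or of compound 2.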